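A few compounds are considered here, and "the series" means these few. Any claim that something is new, unique, unknown or untested is made for them only; others in the source may bear on it.

Working notes on the series. Two compounds have numbers in a functional assay on A549 cells (Homo sapiens) for antiproliferative activity, read by MTT assay, with a stated time of 72 h; a lower number here means a stronger inhibitor, a higher number a weaker inhibitor. Compound 1 `NC1=NC2(CCSCC2)N(OCCCOc2cccc(Cl)c2)C(N)=N1` gives 60 nM in this assay and stands lowest of the two. Going by the values given here, the nearest number belongs to compound 2 `Cc1ccc(OCCCON2C(N)=NC(N)=NC23CCOCC3)cc1`, which in this assay gives 1060 nM, a higher number and beyond the scatter of repeat measurements; compound 2 differs from compound 1 in more than one place, so no single step is drawn between them, and the two values are recorded only as they stand.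

The next compound to be measured is compound 3 `NC1=NC2(CCSCC2)N(OCCCOc2cccc(Br)c2)C(N)=N1`. It differs from compound 1 in one place only: bromo in place of chloro on an aromatic carbon. Among the compounds with values here, nothing so far tests this exchange, since no pair of measured compounds differs by it, and the bearing of such a change on this assay is therefore unknown here.

Within the data shown here, with no step of this kind measured, the expected change from compound 1 is small, a 1.1-fold lower number from compound 1 to compound 3 (0.04 log units; within the scatter), with no direction beyond the scatter. Compound 3 is accordingly estimated at 55 nM in this assay, within a range of 25 nM to 120 nM.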

Compound 3, half-maximal inhibitory concentration: 50 nM
For compound 3 the middle estimate is 1.1-fold (0.04 log units) above the measured one, within the range that was stated.
By their numbers in this assay, from the lowest: compounds 3 and 1 (each within the scatter of the next); then compound 2.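

In this assay the first step measured in this series is bromo in place of chloro on an aromatic carbon, meta to a large group, and it gives a 1.2-fold lower number from compound 1 to compound 3 (0.08 log units; within the scatter). At this place on the six-membered aromatic ring, the 3-chlorophenoxy and 3-bromophenoxy forms therefore cannot be told apart by this read-out, on the core of compound 1 and with the rest of the structure held the same. No measurement at hand accounts for this agreement between the two halogens.

The compounds shown leave open how far this tolerance extends at the same place, as a single exchange between two halogens says nothing about fluoro, or about unlike groups such as methoxy, trifluoromethyl, nitrile or an amine. They also leave open whether the exchange would read the same way with a longer chain joining the aromatic ring to the core, or on a core other than that of compound 1.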